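Acyl chain extension in a thiadiazole glycoside cytotoxicity series

A few compounds are considered here, and "the series" means these few. Any claim that something is new, unique, unknown or untested is made for them only; others in the source may bear on it.

Three acylated members have been measured. Compound 1 `CCCCCCCCCCCC(=O)Nc1nnc(S[C@@H]2O[C@H](COC(C)=O)[C@H](OC(C)=O)[C@H](OC(C)=O)[C@H]2OC(C)=O)s1` gives 51900 nM in a functional assay on HeLa cells (Homo sapiens) for cytotoxicity, read by MTT assay, with a stated time of 24 h; on this read-out lower numbers stand for stronger inhibition and higher numbers for weaker inhibition. Compound 2 `CCCCCCCCCCCCCC(=O)Nc1nnc(S[C@@H]2O[C@H](COC(C)=O)[C@H](OC(C)=O)[C@H](OC(C)=O)[C@H]2OC(C)=O)s1` gives 61300 nM, standing at the top of the three numbers, yet within the scatter of both others. Compound 3 `CCCCCCCC/C=C\CCCCCCCC(=O)Nc1nnc(S[C@@H]2O[C@H](COC(C)=O)[C@H](OC(C)=O)[C@H](OC(C)=O)[C@H]2OC(C)=O)s1` gives 54400 nM in this assay. The steps bearing on the next change are a 1.2-fold higher number from compound 1 to compound 2 (0.07 log units; within the scatter) and a 1.1-fold lower number from compound 2 to compound 3 (0.05 log units; within the scatter); the step of a 1.0-fold higher number from compound 1 to compound 3 (0.02 log units; within the scatter) is equally flat. Compound 4 `CCCCCCCC/C=C\CCCCCCCCCCCC(=O)Nc1nnc(S[C@@H]2O[C@H](COC(C)=O)[C@H](OC(C)=O)[C@H](OC(C)=O)[C@H]2OC(C)=O)s1` differs from compound 2 by dec-1-en-1-yl in place of ethyl on a saturated chain carbon, ten or more bonds along the chain from a carbonyl carbon. Since every earlier chain change left this assay unchanged beyond the scatter, the expected step is a 1.1-fold lower number from compound 2 to compound 4 (0.02 log units; within the scatter), none beyond the scatter. Compound 4 is therefore estimated at 58000 nM, with a range of 30000 nM to 115000 nM.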

Compound 4, half-maximal inhibitory concentration: 58500 nM
The estimate for compound 4 lay 1.0-fold (0.00 log units) below the measured number, and the stated range covers the measured number.
By their numbers in this assay, from the lowest: compounds 1, 3, 4 and 2 (each within the scatter of the next).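

In this assay, at a saturated chain carbon, dec-1-en-1-yl in place of ethyl gives a 1.0-fold lower number from compound 2 to compound 4 (0.02 log units; within the scatter) and dec-1-en-1-yl in place of hydrogen gives a 1.1-fold higher number from compound 1 to compound 4 (0.05 log units; within the scatter). Going by these compounds alone, this far position therefore accepts the larger group with its double bond, and no step leaves the scatter. No available evidence accounts for this flatness. Still open, going by these compounds, is whether a terminal amine or a carboxylic acid on the chain, or a much shorter acyl chain, would move the number beyond the scatter.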